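The compounds below may be only part of what the source reports. "The series", "measured", "known", "first", "only" and "open" are said of these compounds alone.

Measured so far in a toxicity assay on A549 cells (Homo sapiens) for cytotoxicity, read by luminescence and CellTiter-Glo, with a stated time of 48 h; a higher number here means that more compound is tolerated, a lower number that less compound is tolerated:
Compound 1 `CCCCOc1ccc(-c2nc3ncccn3c2NC(C)C)cc1` gives 68000 nM.
Compound 2 `CC(C)(C)CC(C)(C)Nc1nc2ncccn2c1-c1ccc(Br)cc1` gives only a limit, > 100000 nM.
Compound 3 `O=C(O)CCCOc1ccc(-c2nc3ncccn3c2NC2CCCCC2)cc1` gives only a limit, > 100000 nM.

Compound 3 therefore stands at the top of what the assay could report: its value is a limit, not a number. Two of the three compounds sit at the limit of > 100000 nM in this assay, at which 2 of the 3 values shown sit, and only compound 1, which carries no carboxylic acid, gives a measured number, 68000 nM.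

Compound 4 `COc1ccc(-c2nc3ncccn3c2NC2CCCCC2)cc1` differs from compound 3 by hydrogen in place of 2-carboxyethyl on a saturated chain carbon bound to an oxygen on an aromatic ring. For the measured compounds named here, no step between measured compounds is available to gauge this change. Compound 4 is nevertheless expected to fall below the limit by about an at least 1.6-fold lower number from compound 3 to compound 4 (0.22 log units; that floor lies within the scatter), a step beyond the usual scatter, toward where compound 1 sits. The estimate for compound 4 is 60000 nM, within 20000 nM to 150000 nM.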

Compound 4, half-maximal cytotoxic concentration: > 100000 nM
Compound 4: a limit, no number; the forecaster's own chance of this, stated with the estimate: 40%; at least 1.6-fold (0.22 log units) between middle value and limit.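

Compound 3 and compound 4 both give only a limit, not a number, and no step can be read between them: the limit of > 100000 nM in this assay, at which 3 of the 4 values shown sit.

On these data alone, whether methoxy in place of 3-carboxypropoxy changes the tolerated concentration at all remains open.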